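A few compounds are considered here, and "the series" means these few. Any claim that something is new, unique, unknown or untested is made for them only; others in the source may bear on it.

Series notes. Compound 2 `Clc1ccc2c(-n3cc(C4CCCCC4)nn3)ccnc2c1` is the reference point here. In an ADME assay on HepG2 cells (Homo sapiens) for cytotoxicity, read by MTT assay, with a stated time of 24 h (a lower number here means that less compound is tolerated, a higher number that more compound is tolerated), compound 2 reaches only a limit, > 3200 nM. Compound 1 `Fc1ccc(-c2cn(-c3ccnc4cc(Cl)ccc34)nn2)cc1` likewise reaches only a limit in this assay, > 3080000 nM. Within the data shown here, the single measured step, a step that the two limits leave unreadable from compound 1 to compound 2, stays unreadable since both ends sit at limits the limit of > 3080000 nM in this assay, at which 1 of the 2 values shown sits (the limit of > 3200 nM in this assay, at which 1 of the 2 values shown sits). Compound 3 `Clc1ccc2c(-n3cc(CN4CCCCC4)nn3)ccnc2c1` is not yet measured; it differs from compound 2 by (piperidin-1-yl)methyl in place of cyclohexyl on an aromatic carbon. Among the measured compounds shown here, no measured step bears on this change, so no shift beyond the scatter is expected in this assay. Compound 3 is expected near 10000 nM, between 3200 nM and 60000 nM. That estimate means an expected step that the limit leaves unreadable from compound 2 to compound 3.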

Compound 3, half-maximal cytotoxic concentration: 1110000 nM
The estimate for compound 3 lay 110-fold (2.05 log units) below the measured number, and the stated range ends below it.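

In this assay, among these compounds, compound 3 gives the first number at this position that is not a limit, 1110000 nM. Among the compounds shown here, with (piperidin-1-yl)methyl in place of 4-fluorophenyl on an aromatic carbon, the series shows an at least 2.7-fold lower number from compound 1 to compound 3 (0.44 log units; beyond the scatter), the only readable step at this position. Compound 2 holds only a limit, so the steps that touch it cannot be read: the limit of > 3200 nM in this assay, at which 1 of the 3 values shown sits.

Going by these compounds, whether cyclohexyl and (piperidin-1-yl)methyl differ at all remains open. Also open, on these data alone, is how a (morpholin-4-yl)methyl group or a primary amine on a longer chain would read at this position.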